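Swapping a Selenium-Bearing Group for Methylsulfanyl on Two Cores

The compounds below may be only part of what the source reports. "The series", "measured", "known", "first", "only" and "open" are said of these compounds alone.

Of the compounds shown here, three have been tested in a functional assay on HT-29 cells (Homo sapiens) for cytotoxicity, read by MTT assay, with a stated time of 72 h; on this read-out higher numbers stand for weaker inhibition of growth and lower numbers for stronger inhibition of growth. Compound 1 `CS/C(=N\C(=O)c1ccno1)NC(=O)c1ccno1` and compound 2 `O=C(/N=C(/NC(=O)c1ccno1)[Se]Cc1ccccc1)c1ccno1` share one core, while compound 3 `O=C(/N=C(/NC(=O)c1cc(-c2ccccc2)nc2ccccc12)[Se]Cc1ccccc1)c1cc(-c2ccccc2)nc2ccccc12` is built on a second core; the difference between the two cores is not broken down here. In this assay compound 1 gives > 100000 nM, which is a limit of the assay and not a number. In this assay compound 2 likewise reaches only the limit > 100000 nM. In this assay compound 3 also stops at the limit > 100000 nM. The change from compound 2 to compound 1 is a group of 2 heavy atoms (1 carbon, 1 sulfur; no ring) in place of a group of 8 heavy atoms (7 carbon, 1 selenium; one six-membered aromatic ring of carbon only), on a carbon with a double bond to nitrogen, and the step it made, a step that the two limits leave unreadable from compound 2 to compound 1, cannot be read because of the limit of > 100000 nM in this assay, at which 3 of the 3 values shown sit.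

Compound 4 `CS/C(=N\C(=O)c1cc(-c2ccccc2)nc2ccccc12)NC(=O)c1cc(-c2ccccc2)nc2ccccc12` carries the same change on the core of compound 3: a group of 2 heavy atoms (1 carbon, 1 sulfur; no ring) in place of a group of 8 heavy atoms (7 carbon, 1 selenium; one six-membered aromatic ring of carbon only), on a carbon with a double bond to nitrogen. The surroundings of the changed carbon are the same in both pairs, so this is the same change and not merely the same kind. Compound 4 is expected to sit where compound 3 sits because of the limit of > 100000 nM in this assay, at which 3 of the 3 values shown sit. The expected step in this assay is a number no higher from compound 3 to compound 4 (the limit leaves the size open). Compound 4 is therefore estimated at 100000 nM in this assay, with a range from 40000 nM to 250000 nM. The assay is expected most likely to report only a limit for compound 4 once more.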

Compound 4, concentration for total growth inhibition: > 100000 nM
Compound 4 ended at the assay's limit (the forecaster's own chance of this, stated with the estimate: 80%); the middle value lies on the limit itself.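

No new step can be read from compound 3 to compound 4 in this assay, since compound 3 and compound 4 both stop at a limit of the assay and not at a number: the limit of > 100000 nM in this assay, at which 4 of the 4 values shown sit. The compounds shown leave open whether exchanging the selenium-bearing group for methylsulfanyl changes growth inhibition at all on either core.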